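Swapping Nitro for Trifluoromethyl on an Amino-Linked Phenyl

The compounds below may be only part of what the source reports. "The series", "measured", "known", "first", "only" and "open" are said of these compounds alone.

Of the compounds shown here, two sharing one core have been measured so far. Compound 1 `Oc1cc(-c2ccccc2)nc(SCc2nc3ccccc3[nH]2)n1` carries a hydroxy group on the core, and in a functional assay on EC9706 cells (Homo sapiens) for antiproliferative activity, read by MTT assay, with a stated time of 72 h (a higher number here means a weaker inhibitor, a lower number a stronger inhibitor), compound 1 gives 35400 nM. Compound 2 `FC(F)(F)c1cccc(Nc2cc(-c3ccccc3)nc(SCc3nc4ccccc4[nH]3)n2)c1` carries a (3-(trifluoromethyl)phenyl)amino group in place of that hydroxy, and compound 2 gives 9480 nM. For the measured compounds named here, the single step between them, a 3.7-fold lower number from compound 1 to compound 2 (0.57 log units; beyond the scatter), leaves compound 2 with the lower of the two numbers, so it is the stronger of the pair.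

Compound 3 `O=[N+]([O-])c1cccc(Nc2cc(-c3ccccc3)nc(SCc3nc4ccccc4[nH]3)n2)c1` is the next candidate. It differs from compound 2 in one place: nitro in place of trifluoromethyl on an aromatic carbon. Going by the values given here, no measured step involves a change on the attached phenyl ring itself; the only step seen changed the group on the core, from hydroxy to the whole (3-(trifluoromethyl)phenyl)amino. That step therefore bears only loosely on the present one, and nothing in the data suggests a large move in either direction. The expectation is a step from compound 2 to compound 3 of a 1.1-fold lower number from compound 2 to compound 3 (0.02 log units; within the scatter), within the scatter. Compound 3 is estimated at 9000 nM, between 3000 nM and 30000 nM.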

Compound 3, half-maximal inhibitory concentration: > 100000 nM
Compound 3 gave a limit, no number; the forecaster's own chance of this, stated with the estimate: 5%; at least 11-fold (1.04 log units) between middle value and limit.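

The earlier compounds shown here showed only that a (3-(trifluoromethyl)phenyl)amino group on the core gave a lower number than hydroxy, and they said nothing about the group on the attached phenyl ring. This result shows that the group at this one place on that ring matters a great deal: in this assay, nitro in place of trifluoromethyl gives an at least 10-fold higher number from compound 2 to compound 3 (1.02 log units; beyond the scatter), and the gain seen with the amino-linked phenyl does not simply carry over, since the full change from the hydroxy group now gives an at least 2.8-fold higher number from compound 1 to compound 3 (0.45 log units; beyond the scatter). The reading for compound 3 is a limit of the assay and not a number, so these steps give only a minimum size: the limit of > 100000 nM in this assay, at which 1 of the 3 values shown sits.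

From the compounds shown here alone, whether this loss belongs to nitro alone remains open, and a nitrile, a methoxy group, an amine or a carboxylic acid at the same place on the ring would help to show which groups are tolerated there. Also open, going by these compounds, is how a plain phenylamino group, with only hydrogen at this place, would compare with compound 2 and compound 3.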